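Swapping Methyl for Bromo on the Aryl Ring

A few compounds are considered here, and "the series" means these few. Any claim that something is new, unique, unknown or untested is made for them only; others in the source may bear on it.

Compound 1 `CCOC(=O)C1=Cc2ccccc2OC1(OCc1cc(-c2ccc(C)cc2)no1)C(F)(F)F` was tested in a functional assay on HeLa cells (Homo sapiens) for inhibition, read by MTT assay, with a stated time of 24 h (on this read-out lower numbers stand for stronger inhibition and higher numbers for weaker inhibition), where compound 1 gives > 150000 nM, a limit of the assay rather than a number. Compound 2 `CCCCCCCCn1cc(COC2(C(F)(F)F)Oc3ccccc3C=C2C(=O)OCC)nn1` also reaches only a limit in this assay, as compound 2 gives > 150000 nM. Going by the values given here, compound 3 `Cc1ccc(-c2cc(COC3(C(F)(F)F)Oc4ccccc4C=C3C(=O)O)on2)cc1` is the only compound with a measured number: in this assay compound 3 gives 33400 nM. Among the compounds with values here, the one measured step, an at least 4.4-fold lower number from compound 1 to compound 3 (0.65 log units; beyond the scatter), turns the ester into the acid and therefore tells nothing about the aryl group at the far end of the molecule. As far as these compounds go, compound 1 thus stands at the limit of > 150000 nM in this assay, at which 2 of the 3 values shown sit, and where it truly lies beyond that is unknown. Compound 4 `CCOC(=O)C1=Cc2ccccc2OC1(OCc1cc(-c2ccc(Br)cc2)no1)C(F)(F)F` differs from compound 1 by bromo in place of methyl on an aromatic carbon. Within the data shown here, no measured step touches this part of the molecule, so no change beyond the scatter is expected in this assay. Compound 4 is therefore expected to give about 200000 nM, in the range 100000 nM to 400000 nM, most probably reported again as a limit, so that a step that the limit leaves unreadable from compound 1 to compound 4 is estimated to stay within the scatter.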

Compound 4, half-maximal inhibitory concentration: 52300 nM
Estimate against measurement, compound 4: 3.8-fold (0.58 log units) above; the measured number lies below the stated range.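

The far end of the molecule, which the earlier step from ester to acid left untouched, proves able to move the read-out: changing 4-methylphenyl to 4-bromophenyl gives an at least 2.8-fold lower number from compound 1 to compound 4 (0.45 log units; beyond the scatter) in this assay. The ethyl ester therefore does not by itself keep a compound at the limit, since compound 4 keeps that ester and still gives a measured number. The true size of this step stays unknown because compound 1 is held only by a limit: the limit of > 150000 nM in this assay, at which 2 of the 4 values shown sit.

As far as these compounds go, whether bromo in place of methyl also lowers the number when the carboxylic acid of compound 3 replaces the ester remains open. From the compounds shown here alone, it is also open how other groups at this place on the ring, such as a chloro, a methoxy or an amine, would compare with bromo.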